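This account rests on a few compounds, and the source may have more. Where it says the series, first, only, none or still open, it means among the compounds named here.

Measured so far:
- compound 1, `Cc1cn(Cc2cc(Br)ccc2OCc2ccccc2)nc1C(=O)O`: 1350 nM
- compound 2, `O=C(O)c1nn(Cc2cc(Br)ccc2OCc2ccccc2)cc1C(F)(F)F`: < 2000 nM

In a functional assay on CHO-K1 cells for antagonist activity at prostaglandin E2 receptor EP1 subtype (Homo sapiens), read by FLIPR (on this read-out higher numbers stand for weaker inhibition and lower numbers for stronger inhibition), compound 1 gives 1350 nM. For compound 2 this assay returns only a limit, < 2000 nM, so its position among the numbers shown is not fixed; the step that the limit leaves unreadable from compound 1 to compound 2 is therefore unreadable, and the limit of < 2000 nM in this assay, at which 1 of the 2 values shown sits, is the only evidence bearing on the change at this ring carbon.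

Compound 3, `O=C(O)c1nn(Cc2cc(Br)ccc2OCc2ccccc2)cc1Cl`, differs from compound 2 by chloro in place of trifluoromethyl on an aromatic carbon. Among the compounds with values here, only one measured step concerns this carbon, and since that step from compound 1 to compound 2 cannot be read, no size or direction is available for swapping one small group for another here. The working expectation is that compound 3 stays near compound 1 in this assay, with the step that the limit leaves unreadable from compound 2 to compound 3 expected to lie within the usual scatter rather than beyond it. Compound 3 is thus estimated at 1300 nM, with a range from 350 nM to 5000 nM.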

Compound 3, inhibition constant: < 2000 nM
Compound 3 ended at the assay's limit; the forecaster's own chance of this, stated with the estimate: 25%; the middle value does not contradict the limit.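

In this assay, within the data shown here, compound 3 gives < 2000 nM as a limit and not a number, so no step among compound 1, compound 2 and compound 3 can be read. The compounds shown leave open how methyl, trifluoromethyl and chloro on this aromatic carbon rank, with one shared limit as the only evidence: the limit of < 2000 nM in this assay, at which 2 of the 3 values shown sit.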